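From 4-Nitrophenyl to 3-Methoxyphenyl on a Carbonyl Carbon

The source may report more compounds than this note shows. Statements on the series, on what has been measured and on what is new or still open speak of the compounds shown alone.

Of the compounds shown here, three built on one shared core have so far been measured in an assay on isolated protein for inhibition of Indoleamine 2,3-dioxygenase 1 (Homo sapiens), with a stated time of 60 min, tested at 1 uM; on this read-out higher numbers stand for more inhibition at the one concentration tested (going by the name of the read-out) and lower numbers for less inhibition. Compound 1 `CC(=O)N(C)CC(=O)NCc1cnc2scc(-c3ccc(Br)cc3)n12` gives 21%. Compound 2 `CN(CC(=O)NCc1cnc2scc(-c3ccc(Br)cc3)n12)C(=O)c1ccccc1` gives 50%, and compound 3 `CN(CC(=O)NCc1cnc2scc(-c3ccc(Br)cc3)n12)C(=O)c1ccc([N+](=O)[O-])cc1` gives 45%. Compound 3 thus stands second highest of the three numbers: its value and that of compound 2 lie within the scatter of each other, since a number 5 percentage points lower from compound 2 to compound 3 (within the scatter), while it sits clearly above compound 1, since a number 24 percentage points higher from compound 1 to compound 3 (beyond the scatter).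

Compound 4 `COc1cccc(C(=O)N(C)CC(=O)NCc2cnc3scc(-c4ccc(Br)cc4)n23)c1` has not yet been measured. 3-methoxyphenyl in place of 4-nitrophenyl on a carbonyl carbon Two measured steps bear on this change. The steps of a number 29 percentage points higher from compound 1 to compound 2 (beyond the scatter) and a number 24 percentage points higher from compound 1 to compound 3 (beyond the scatter) show that replacing methyl by either aryl group on the carbonyl carbon lifts inhibition by a modest, similar amount, and a number 5 percentage points lower from compound 2 to compound 3 (within the scatter) shows that the substituent on the aryl ring hardly moved the number. Only these two aryl variants exist, so nothing can be said about a methoxy group as such; a third aryl group is expected to land near the aryl pair. The step of a number 2 percentage points higher from compound 3 to compound 4 (within the scatter) is therefore expected to stay within the scatter. Compound 4 is estimated at 47%, with a range from 32% to 62%.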

Compound 4, a percentage reported as inhibition, at one concentration (the size of the read-out at that concentration, not a potency): 48%
Estimate against measurement, compound 4: 1 percentage points below, within the range that was stated.
By their numbers in this assay, from the lowest: compound 1; then compounds 3, 4 and 2 (each within the scatter of the next).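

In this assay the gain over methyl on the carbonyl carbon now extends to a third aryl group (a number 27 percentage points higher from compound 1 to compound 4 (beyond the scatter)), so phenyl, 4-nitrophenyl and 3-methoxyphenyl all share it and none of the compounds shown goes against it. The substituted rings also remain indistinguishable from each other (a number 3 percentage points higher from compound 3 to compound 4 (within the scatter)) and from the plain phenyl ring (a number 2 percentage points lower from compound 2 to compound 4 (within the scatter)), which means that neither the nitro group nor the methoxy group, each at the place its name states, separates from hydrogen on this read-out. Nothing available here accounts for these numbers.

Going by these compounds, all the groups compared on the carbonyl carbon are either methyl or a six-membered aromatic ring of carbon only, so it remains open whether a cyclohexyl ring, a longer alkyl chain or a pyridine ring would match the aryl compounds or fall back towards compound 1. On these data alone, it also remains open whether an amine or a carboxylic acid on the phenyl ring would stay within the scatter of compound 2, as the nitro and methoxy groups do.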